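A few compounds are considered here, and "the series" means these few. Any claim that something is new, unique, unknown or untested is made for them only; others in the source may bear on it.

Values in a functional assay on HEK293 cells for agonist activity at G-protein coupled receptor 39 (Homo sapiens), read by scintillation proximity assay and inositol phosphate accumulation, with a stated time of 75 min, in the presence of a further agent that is not named here (a lower number here means that less compound is needed, a higher number that more compound is needed for the effect), for the three measured compounds:
compound 1 `Cc1nn(-c2ncnc3nc[nH]c23)c2c1C(OCC(=O)c1ccc(F)cc1)CC(=O)N2` gives 3 nM
compound 2 `Cc1nn(-c2ncnc3nc[nH]c23)c2c1C(C(=O)NCc1ccccc1)CC(=O)N2` gives 5 nM
compound 3 `Cc1noc(C)c1COC1CC(=O)Nc2c1c(C)nn2-c1ncnc2nc[nH]c12` gives 5 nM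

Compound 3 stands level with compound 2 at the digits shown, the two numerically the higher of the three; compound 1 sits a 1.7-fold higher number from compound 1 to compound 3 (0.22 log units; within the scatter) away, and the pair with compound 2 reads no change at the digits printed from compound 2 to compound 3 (within the scatter). All three lie within the scatter of one another, so no order among them can be read.

Compound 4 `Cc1nn(-c2ncnc3nc[nH]c23)c2c1C(OCc1ccc(F)cc1)CC(=O)N2` is not yet measured. The change from compound 3: 4-fluorophenyl in place of 3,5-dimethyl-1,2-oxazol-4-yl on a saturated chain carbon bound to an oxygen on a saturated carbon. For the measured compounds named here, compound 4 thus carries the same 4-fluorophenyl ring as compound 1 on the ether chain, but on a saturated carbon where compound 1 has a carbonyl; no step between compound 1 and compound 4 is recorded, so that pair is not compared directly. Going by the values given here, the one recorded step that bears on this change, a 1.7-fold higher number from compound 1 to compound 3 (0.22 log units; within the scatter), was within the scatter, and the exchange of the whole substituent from compound 2 to compound 3, no change at the digits printed from compound 2 to compound 3 (within the scatter), also moved nothing. The step to compound 4 is therefore expected to stay within the scatter, at most a small move to a lower number: a 1.4-fold lower number from compound 3 to compound 4 (0.15 log units; within the scatter). The estimate for compound 4 in this assay is 3.5 nM, range 1.5 nM to 9 nM.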

Compound 4, half-maximal effective concentration: 1 nM
For compound 4 the middle estimate is 3.5-fold (0.54 log units) above the measured one; the whole stated range lies above it.
By their numbers in this assay, from the lowest: compound 4; then compounds 1, 2 and 3 (each within the scatter of the next).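

In this assay the ether chain on the saturated ring carbon gives the first separation in this set: the earlier changes at this place stayed within the scatter, whereas a 5.0-fold lower number from compound 3 to compound 4 (0.70 log units; beyond the scatter) follows from 4-fluorophenyl replacing 3,5-dimethyl-1,2-oxazol-4-yl on the saturated chain carbon bound to an oxygen. Removing the carbonyl from the chain while retaining the 4-fluorophenyl ring gives a 3.0-fold lower number from compound 1 to compound 4 (0.48 log units; beyond the scatter) and so separates two compounds that share that ring, while the exchange of benzylcarbamoyl for (4-fluorobenzyl)oxy gives a 5.0-fold lower number from compound 2 to compound 4 (0.70 log units; beyond the scatter) as a further modest step. Compound 4 therefore has the lowest number of the four, its steps to all the others being beyond the scatter, but no measurement at hand offers an explanation for these steps.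

Going by these compounds, the role of the fluorine stays open, since the set holds no plain benzyl ether and no 4-chlorobenzyl ether for comparison with the 4-fluorobenzyl group. Also open, on these data alone, is whether a longer chain, such as 2-phenylethyl on the oxygen, or an amine in place of the ether oxygen would keep the number this low.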